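Moving the halogen around the benzyl ether of compound 1

The source may report more compounds than this note shows. Statements on the series, on what has been measured and on what is new or still open speak of the compounds shown alone.

compound 1 `CCc1nncn1-c1ccc(OCc2ccc(F)cc2)cc1`: 22.8 mg/kg
compound 2 `CCc1nncn1-c1ccc(OCc2ccccc2F)cc1`: 21.2 mg/kg
compound 3 `CCc1nncn1-c1ccc(OCc2ccc(Cl)cc2)cc1`: 19.7 mg/kg

In a functional assay on the whole organism (strain C57B/6) with Mus musculus as the target, in the maximal electroshock model (a higher number here means that more compound is needed for the effect, a lower number that less compound is needed), compound 1 has the highest of the three numbers, yet both of its steps to the others, a 1.1-fold lower number from compound 1 to compound 2 (0.03 log units; within the scatter) and a 1.2-fold lower number from compound 1 to compound 3 (0.06 log units; within the scatter), stay within the scatter, so the three compounds are not separated. Compound 4 `CCc1nncn1-c1ccc(OCc2cccc(Cl)c2)cc1` brings (3-chlorophenyl in place of 4-fluorophenyl on a saturated chain carbon bound to an oxygen on an aromatic ring). Going by the values given here, two measured steps bear on this change: swapping the halogen, a 1.2-fold lower number from compound 1 to compound 3 (0.06 log units; within the scatter), and moving a halogen to another position on the ring, a 1.1-fold lower number from compound 1 to compound 2 (0.03 log units; within the scatter). Neither moved the number beyond the scatter, and compound 4 combines a move of position with a swap of halogen. No step beyond the scatter is therefore expected, a 1.1-fold lower number from compound 1 to compound 4 (0.06 log units; within the scatter). Compound 4 is estimated at 20 mg/kg, with a range from 11 mg/kg to 36 mg/kg.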

Compound 4, dose for half-maximal effect: 27.4 mg/kg
For compound 4 the middle estimate is 1.4-fold (0.14 log units) below the measured one, and the stated range covers the measured number.
By their numbers in this assay, from the lowest: compounds 3, 2, 1 and 4 (each within the scatter of the next).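

In this assay, putting 3-chlorophenyl on the saturated chain carbon bound to an oxygen on an aromatic ring gives a 1.2-fold higher number from compound 1 to compound 4 (0.08 log units; within the scatter) and a 1.4-fold higher number from compound 3 to compound 4 (0.14 log units; within the scatter) and a 1.3-fold higher number from compound 2 to compound 4 (0.11 log units; within the scatter). All three steps stay within the scatter, so the four halogen-bearing phenyl groups are not separated, and compound 4 adds a further chlorine placement that leaves them so. No measurement is available to explain these numbers. On these data alone, what stays open is whether an amine, a carboxylic acid or a longer chain in place of the halogen on this phenyl ring would give a step beyond the scatter.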